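Compound 3 and the piperazin-1-yl exchange

The source may report more compounds than this note shows. Statements on the series, on what has been measured and on what is new or still open speak of the compounds shown alone.

In a functional assay on V79 cells (Cricetulus griseus) for cytotoxicity, read by colony formation (on this read-out higher numbers stand for weaker inhibition and lower numbers for stronger inhibition), compound 3 (`CNCC1(C)CCN(c2c(F)cc3c(=O)c(C(=O)O)cn(C4CC4)c3c2C(F)(F)F)C1`) gives 230 ug/mL as its half-maximal inhibitory concentration. Compound 2 (`CNCC1(C)CCN(c2c(F)cc3c(=O)c(C(=O)O)cn(C4CC4)c3c2OC)C1`) gives 120 ug/mL and cannot be told apart from it: the measured step is a 1.9-fold higher number from compound 2 to compound 3 (0.28 log units; within the scatter) and it concerns trifluoromethyl in place of methoxy on an aromatic carbon. Compound 1 (`NCC1CCN(c2c(F)cc3c(=O)c(C(=O)O)cn(C4CC4)c3c2C(F)(F)F)C1`) gives 38 ug/mL and stands clearly lower than compound 3.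

Compound 4 (`O=C(O)c1cn(C2CC2)c2c(C(F)(F)F)c(N3CCNCC3)c(F)cc2c1=O`) carries piperazin-1-yl in place of 3-methyl-3-((methylamino)methyl)pyrrolidin-1-yl on an aromatic carbon, ortho to a fluoro group and ortho to a trifluoromethyl group (piperazin-1-yl in place of 3-methyl-3-((methylamino)methyl)pyrrolidin-1-yl on an aromatic carbon). Among the measured compounds shown here, only one measured step changes that same place, namely a 6.1-fold higher number from compound 1 to compound 3 (0.78 log units; beyond the scatter) for the opposite kind of exchange, with 3-(aminomethyl)pyrrolidin-1-yl leaving. For the measured compounds named here, no measured compound holds piperazin-1-yl, so this step guides the direction more than the size. Compound 1 (38 ug/mL) shows that a number well under that of compound 3 is reachable without the group that compound 4 also gives up, so a lower number is expected, by a modest step smaller than the measured one. The expected change is (a 2.6-fold lower number from compound 3 to compound 4 (0.41 log units; beyond the scatter)) in this read-out. Compound 4 is estimated at 90 ug/mL in this assay, with an expected range from 30 ug/mL to 250 ug/mL for a measurement.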

Compound 4, half-maximal inhibitory concentration: 1650 ug/mL
For compound 4 the middle estimate is 18-fold (1.26 log units) below the measured one; measured number outside the range, above it.
By their numbers in this assay, from the lowest: compound 1; then compounds 2 and 3 (each within the scatter of the next); then compound 4.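

At the aromatic carbon ortho to a fluoro group and ortho to a trifluoromethyl group, piperazin-1-yl moves the number in this assay upward from both pyrrolidine-bearing compounds, with a 7.2-fold higher number from compound 3 to compound 4 (0.86 log units; beyond the scatter) and a 43-fold higher number from compound 1 to compound 4 (1.64 log units; beyond the scatter). The earlier compounds had shown only a difference between two five-membered rings at this place, and the six-membered ring now widens the span reached by changing this one group on the shared core. Giving up 3-methyl-3-((methylamino)methyl)pyrrolidin-1-yl therefore does not by itself bring the number toward that of compound 1, so the group that enters counts as well as the group that leaves.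

No measurement is at hand that explains why the number rises with this exchange. On these data alone, it also stays open whether the rise belongs to the piperazine ring as such, whether it would persist with 4-methylpiperazin-1-yl or 3-aminopyrrolidin-1-yl at the same carbon, and whether it would hold with methoxy instead of trifluoromethyl on the neighbouring position of the core.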